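Swapping an amino for a chloro on a shared core

A few compounds are considered here, and "the series" means these few. Any claim that something is new, unique, unknown or untested is made for them only; others in the source may bear on it.

Of the compounds shown here, three that share one large aromatic core have been measured in a functional assay, with a stated time of 90 s; on this read-out lower numbers stand for stronger inhibition and higher numbers for weaker inhibition. Compound 1 `Cc1nc2c3ccccc3ccc2c2nc3c(ccc4ccccc43)c(-c3nccnc3N)c12` carries a 3-aminopyrazin-2-yl group and gives 134 ug/mL. Compound 2 `Cc1nc2c3ccccc3ccc2c2nc3c(ccc4ccccc43)c(-c3cccc4ccccc34)c12` carries a naphthalen-1-yl group at the same place and gives 179 ug/mL. Compound 3 `Cc1nc2c3ccccc3ccc2c2nc3c(ccc4ccccc43)c(-c3ccccc3N)c12` carries a 2-aminophenyl group and gives 125 ug/mL. The three numbers sit close together: the step of a 1.1-fold lower number from compound 1 to compound 3 (0.03 log units; within the scatter) and the step of a 1.4-fold lower number from compound 2 to compound 3 (0.16 log units; within the scatter) both lie within the scatter, and so does a 1.3-fold higher number from compound 1 to compound 2 (0.13 log units; within the scatter), so compound 3 is not separated from the other two.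

Compound 4 `Cc1nc2c3ccccc3ccc2c2nc3c(ccc4ccccc43)c(-c3ccccc3Cl)c12` is not yet measured. Compared with compound 3 the change is chloro in place of amino on an aromatic carbon. Among the compounds with values here, no measured pair shows a chloro replacing an amino, so there is no direct precedent. Within the data shown here, the steps that bear on it are the changes of the group at this same position, from compound 1 and compound 2 to compound 3, and each of them stayed within the scatter even when the whole group was exchanged. On that basis a step of a 1.2-fold higher number from compound 3 to compound 4 (0.08 log units; within the scatter) is expected, that is, no change beyond the scatter, in either direction. Compound 4 is therefore estimated at 150 ug/mL, with a range from 70 ug/mL to 320 ug/mL.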

Compound 4, half-maximal inhibitory concentration: 170 ug/mL
Beside the measured number, compound 4's estimate is 1.1-fold (0.05 log units) below it; the range from low to high includes it.
By their numbers in this assay, from the lowest: compounds 3, 1, 4 and 2 (each within the scatter of the next).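

In this assay, within the data shown here, the step of a 1.4-fold higher number from compound 3 to compound 4 (0.13 log units; within the scatter) is the first measured exchange of a single atom at this position rather than of a whole group, and it separates the two compounds by no more than ordinary assay noise. The amino group brings a hydrogen-bond donor and a hydrogen-bond acceptor while the chloro brings neither, so this read-out gives no sign that the amino group is needed here. The other two comparisons agree, with the step of a 1.1-fold lower number from compound 2 to compound 4 (0.02 log units; within the scatter) and the step of a 1.3-fold higher number from compound 1 to compound 4 (0.10 log units; within the scatter) also giving no separation, so all four groups tried at this place remain indistinguishable in this assay, and no measurement at hand explains this result.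

Still open, going by these compounds, is whether any group at this position can move the number beyond the scatter, such as a hydroxyl, a methoxy or a carboxylic acid on the same ring. Also open, on these data alone, is whether a chloro would behave the same way on the pyrazine ring of compound 1, as a 3-chloropyrazin-2-yl group.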